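Swapping a cyclopropylmethyl for a 2-bromophenyl

The source may hold more compounds than are shown below. What is called first, only, known or untested is meant among the compounds shown, and "the series" means these compounds.

Compound 1 `CN1C(=O)C(CC2CC2)N(C)c2nc(Nc3ccc(S(N)(=O)=O)cc3)ncc21`: 211 nM
Compound 2 `CN1C(=O)C(c2ccccc2F)N(C)c2nc(Nc3ccc(S(N)(=O)=O)cc3)ncc21`: 75 nM

In an assay on Sf9 cells for inhibition of serine/threonine-protein kinase 4 (Homo sapiens), read by luminescence and ADP-Glo, with a stated time of 1 h, in the presence of a further agent that is not named here (on this read-out higher numbers stand for weaker inhibition and lower numbers for stronger inhibition), compound 1 gives 211 nM, the highest of the two numbers measured; compound 2 gives 75 nM. Compound 3 `CN1C(=O)C(c2ccccc2Br)N(C)c2nc(Nc3ccc(S(N)(=O)=O)cc3)ncc21` differs from compound 1 in one place: 2-bromophenyl in place of cyclopropylmethyl on a saturated ring carbon. Among the measured compounds shown here, the only measured step that bears on this change is a 2.8-fold lower number from compound 1 to compound 2 (0.45 log units; beyond the scatter), a modest drop beyond the scatter. A step of similar size and direction is expected here. Compound 3 is therefore estimated at 80 nM, with a likely range from 30 nM to 250 nM. The expected step is a 2.6-fold lower number from compound 1 to compound 3 (0.42 log units; beyond the scatter).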

Compound 3, half-maximal inhibitory concentration: 57 nM
Beside the measured number, compound 3's estimate is 1.4-fold (0.15 log units) above it; low and high end bracket the measured number.
By their numbers in this assay, from the lowest: compounds 3 and 2 (each within the scatter of the next); then compound 1.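

Compound 3 shows that the gain over cyclopropylmethyl at this saturated ring carbon is not tied to 2-fluorophenyl: 2-bromophenyl gives a 3.7-fold lower number from compound 1 to compound 3 (0.57 log units; beyond the scatter) as well. Bromo in place of fluoro gives a 1.3-fold lower number from compound 2 to compound 3 (0.12 log units; within the scatter) on this read-out, so the two halogens cannot be told apart here. No evidence is available on why either phenyl group gives the lower number.

Going by these compounds, whether a plain phenyl without a halogen would do the same stays open. So does the outcome with a methoxy group or an amine on that ring.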